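Chloro to Methoxy: Expecting Compound 4

This account rests on a few compounds, and the source may have more. Where it says the series, first, only, none or still open, it means among the compounds named here.

In a functional assay on the whole organism (strain Wistar) for inhibition, with Rattus norvegicus as the target, with stated times of 30 min and 2 h, at a dose of 20 mg/kg by the oral route (a higher number here means more inhibition at the dose given (going by the name of the read-out), a lower number less inhibition), compound 3 `Cc1ccc(C(=O)CCc2nnc(-c3ccc(Cl)cc3)o2)c(C)c1` gives 53.3%, the second highest of three numbers: compound 1 `COc1ccc(-c2nnc(CCC(=O)c3ccc(C)cc3)o2)cc1` gives 69.3%, while compound 2 `Cc1ccc(C(=O)CCc2nnc(-c3ccccc3)o2)c(C)c1` gives 36%. For the measured compounds named here, the only measured step so far, a number 17.3 percentage points higher from compound 2 to compound 3 (beyond the scatter), came from chloro in place of hydrogen on an aromatic carbon. Compound 4 `COc1ccc(-c2nnc(CCC(=O)c3ccc(C)cc3C)o2)cc1` instead carries methoxy in place of chloro on an aromatic carbon. Going by the values given here, no measured step covers this exchange, so the expectation rests only on compound 1 with 69.3% set against compound 3 with 53.3%, where compound 1 carries methoxy where compound 3 carries chloro, though the two also differ at one other place. A step of a number 7.7 percentage points higher from compound 3 to compound 4 (within the scatter) is therefore expected, upward but uncertain. Compound 4 is estimated at 61%, between 46% and 76%.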

Compound 4, a percentage reported as inhibition, in the whole organism at one dose (the size of the read-out at that dose, not a potency): 62.7%
Compound 4: the middle estimate sits 1.7 percentage points below what was measured, within the range that was stated.
By their numbers in this assay, from the lowest: compound 2; then compounds 3, 4 and 1 (each within the scatter of the next, the first and the last beyond it).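

At this place, para to a large group, going from 4-chlorophenyl to 4-methoxyphenyl gives a number 9.4 percentage points higher from compound 3 to compound 4 (within the scatter), so chloro and methoxy cannot be told apart here. Methoxy in place of hydrogen gives a number 26.7 percentage points higher from compound 2 to compound 4 (beyond the scatter), so both groups tried at this place now stand clear of hydrogen, a step that chloro alone had shown before. The added methyl on an aromatic carbon gives a number 6.6 percentage points lower from compound 1 to compound 4 (within the scatter), so it cannot be told apart from hydrogen at its place.

From the compounds shown here alone, whether an amine or a carboxylic acid at the methoxy position would behave like these two groups remains open. Why a group here matters also stays unexplained, as no measurement addresses it.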